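From 3-bromophenyl to 4-bromophenyl in a narrow series

The source may hold more compounds than are shown below. What is called first, only, known or untested is meant among the compounds shown, and "the series" means these compounds.

In a functional assay on HepG2 cells (Homo sapiens) for antiproliferative activity, read by MTT assay, with a stated time of 24 h (a higher number here means a weaker inhibitor, a lower number a stronger inhibitor), compound 1 `c1ccc(Cc2nnc(Cn3nnc4ccccc43)o2)cc1` gives 369000 nM and compound 2 `COc1ccccc1Cc1nnc(Cn2nnc3ccccc32)o1` gives 334000 nM. Compound 3 `Brc1cccc(-c2nnc(Cn3nnc4ccccc43)o2)c1` gives 488000 nM, within the scatter of both. Compound 4 `Brc1ccc(-c2nnc(Cn3nnc4ccccc43)o2)cc1` has the same atoms joined differently, with 4-bromophenyl in place of 3-bromophenyl on an aromatic carbon of the five-membered aromatic ring with 2 nitrogen and 1 oxygen: 4-bromophenyl in place of 3-bromophenyl on an aromatic carbon.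

Going by the values given here, no measured pair tests this change directly, so the evidence is indirect. Among the compounds with values here, two steps bear on it: the methoxy change is a 1.1-fold lower number from compound 1 to compound 2 (0.04 log units; within the scatter), and the replacement of benzyl by 3-bromophenyl is a 1.3-fold higher number from compound 1 to compound 3 (0.12 log units; within the scatter). Neither step leaves the scatter, and the second is the closer guide since it introduces the bromine-bearing ring. No shift beyond the scatter is therefore expected in this assay, and no firm direction can be assigned. The expected step is a 1.2-fold lower number from compound 3 to compound 4 (0.09 log units; within the scatter). Compound 4 is estimated at 400000 nM, with an expected range of 220000 nM to 720000 nM.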

Compound 4, half-maximal inhibitory concentration: 438000 nM
Beside the measured number, compound 4's estimate is 1.1-fold (0.04 log units) below it; the range from low to high includes it.
By their numbers in this assay, from the lowest: compounds 2, 1, 4 and 3 (each within the scatter of the next).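

Going by these compounds alone, exchanging 3-bromophenyl for 4-bromophenyl on this aromatic carbon gives a 1.1-fold lower number from compound 3 to compound 4 (0.05 log units; within the scatter) in this assay and so adds a first direct reading of where the bromine sits on the ring, one that stays inside the scatter. Putting 4-bromophenyl in place of benzyl gives a 1.2-fold higher number from compound 1 to compound 4 (0.07 log units; within the scatter) and this too stays inside the scatter, so the two bromophenyl compounds and the benzyl compound 1 cannot be told apart in this assay. No evidence is at hand to explain why these numbers stay so close.

The compounds shown leave open whether any group at this aromatic carbon can move the number beyond the scatter. An amine or a carboxylic acid on the phenyl ring, or a longer chain in place of benzyl, would test this.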